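The compounds below may be only part of what the source reports. "The series", "measured", "known", "first", "only" and "open" are said of these compounds alone.

Measured so far, all in a functional assay on HEK293 cells for agonist activity at Free fatty acid receptor 1 (Homo sapiens), read by fluorescence and calcium flux, with a stated time of 10 min; a lower number here means a smaller maximal response, a higher number a larger maximal response:
Compound 1, `COc1ccc2c(c1)OC(COc1ccc(CCC(=O)O)c(F)c1)CC2`, gives 58%.
Compound 2, `COc1ccc2c(c1)OC(COc1ccc(CCC(=O)O)c(F)c1)CO2`, gives 80%.
Compound 3, `CC#CC(CC(=O)O)c1ccc(OCC2COc3ccc(Cl)cc3O2)cc1`, gives 104%.

Among these three, compound 3 stands highest. Compound 2 comes nearest, its largest response lying lower by a margin beyond the usual scatter, and compound 1 lies furthest, lower still and also beyond the scatter. No two of the measured compounds differ in only one place, so no single change can be followed within the measured set.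

Compound 4, `O=C(O)CC(c1ccc(F)cc1)c1ccc(OCC2COc3ccc(Cl)cc3O2)cc1`, has not yet been tested in this assay. It differs from compound 3 in one place: 4-fluorophenyl in place of prop-1-yn-1-yl on a saturated chain carbon bound to an aromatic carbon and a saturated chain carbon. The prop-1-yn-1-yl group leaves and 4-fluorophenyl enters, the rest of the molecule being kept. Going by the values given here, no measured pair shows what such a change does to the largest response, so the expectation rests on compound 3 alone. The value of compound 3 in this assay, 104%, leaves little room above, so a rise beyond the scatter is not expected; a result within the scatter or a modest fall seems more likely. The expected step is a number 12 percentage points lower from compound 3 to compound 4 (beyond the scatter). Compound 4 is therefore estimated at 92%, in a range from 65% to 112%.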

Compound 4, largest response reached (Emax), in percent of the reference or control that the assay uses: 83%
Compound 4: the middle estimate sits 9 percentage points above what was measured; the measured number falls inside the stated range.
By their numbers in this assay, from the lowest: compound 1; then compounds 2 and 4 (each within the scatter of the next); then compound 3.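

In this assay, the saturated chain carbon bound to an aromatic carbon and a saturated chain carbon turns out to be a place where the group matters: 4-fluorophenyl in place of prop-1-yn-1-yl gives a number 21 percentage points lower from compound 3 to compound 4 (beyond the scatter). This is the first single change that can be followed among these compounds, and it shows that the larger aromatic group costs part of the maximal response without abolishing it, with compound 4 still reaching 83%. Nothing available bears on the reason for this fall.

On these data alone, it remains open whether the fall belongs to the aromatic ring itself or to its fluorine, and whether a plain phenyl, a methyl or a longer alkyne at this place would sit nearer to compound 3 or to compound 4. The step also rests on this single pair, so whether the same exchange would have a similar effect on another core, or on any read-out other than the largest response, stays unanswered.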